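Does a five-membered aromatic ring change the picture?

The source may report more compounds than this note shows. Statements on the series, on what has been measured and on what is new or still open speak of the compounds shown alone.

Compound 1 `COc1cc(OC)c2c(=O)c(OCC(=O)N/N=C/c3ccc(C)cc3)c(-c3cc(OC)c(OC)c(OC)c3)oc2c1`: 4570 nM
Compound 2 `COc1cc(OC)c2c(=O)c(OCCCCN3CCN(C)CC3)c(-c3cc(OC)c(OC)c(OC)c3)oc2c1`: 3870 nM

Both numbers come from a functional assay on MDA-MB-231 cells (Homo sapiens) for cytotoxicity, read by MTT assay, with a stated time of 38 h (on this read-out higher numbers stand for weaker inhibition and lower numbers for stronger inhibition), and are all that is known so far. For the measured compounds named here, compound 2 stands at 3870 nM on this short scale, with compound 1 as its only neighbour. Going by the values given here, the one measured step is a 1.2-fold lower number from compound 1 to compound 2 (0.07 log units; within the scatter) and it lies within the scatter, so exchanging these two side groups on the shared core showed no real difference.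

Compound 3 `COc1cc(OC)c2c(=O)c(OCC(=O)N/N=C/c3ccco3)c(-c3cc(OC)c(OC)c(OC)c3)oc2c1` has no number yet. The change is a group of 10 heavy atoms (6 carbon, 2 nitrogen, 2 oxygen; one five-membered aromatic ring with 1 hetero atom) in place of a group of 10 heavy atoms (8 carbon, 2 nitrogen; one six-membered non-aromatic ring with 2 hetero atoms), on a saturated chain carbon bound to an oxygen on an aromatic ring and it restores a side group much like that of compound 1, but with a five-membered aromatic ring in place of a six-membered aromatic ring of carbon only. Among the compounds with values here, no measurement yet tests that ring swap directly. The small step of a 1.2-fold lower number from compound 1 to compound 2 (0.07 log units; within the scatter) offers no reason to expect a large move in this assay in either direction. The estimated step is a 1.0-fold higher number from compound 2 to compound 3 (0.01 log units; within the scatter) and no shift beyond the scatter is expected. Compound 3 is expected at 4000 nM with an estimated range from 1700 nM to 9000 nM for now.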

Compound 3, half-maximal inhibitory concentration: 1860 nM
Estimate against measurement, compound 3: 2.2-fold (0.33 log units) above; the measured number falls inside the stated range.
By their numbers in this assay, from the lowest: compound 3; then compounds 2 and 1 (each within the scatter of the next).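

In this assay, for the compounds shown here, exchanging 4-methylphenyl for furan-2-yl on a carbon with a double bond to nitrogen gives a 2.5-fold lower number from compound 1 to compound 3 (0.39 log units; beyond the scatter) and is the first change here to pass beyond the scatter, so the ring at the end of this side group does register in the read-out, if only modestly. The side group of compound 3 also separates from the 3-(4-methylpiperazin-1-yl)propyl group, with a 2.1-fold lower number from compound 2 to compound 3 (0.32 log units; beyond the scatter) on the same scale, whereas compound 1 and compound 2 could not be told apart. Nothing measured here explains why the furan-2-yl compound gives the lower number.

The step from compound 1 to compound 3 changes the ring size, brings in a ring oxygen and removes the methyl group all at once, so the compounds shown do not say which of these matters. Going by these compounds, a plain phenyl ring or a thiophene ring, which has sulfur in place of the furan oxygen, at the same place could start to separate these features, and whether the step holds in other cell lines stays open.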